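The source may report more compounds than this note shows. Statements on the series, on what has been measured and on what is new or still open speak of the compounds shown alone.

Three members of the series have values in an ADME assay on Caco-2 cells (Homo sapiens) for permeability, in the apical to basolateral direction; on this read-out higher numbers stand for higher permeability and lower numbers for lower permeability. Compound 1 `CNC(=O)c1cc(Oc2ccc3nc(Nc4cccc(Cl)c4)ncc3c2)ccn1` gives < 1 10^-6 cm/s, which is a limit of the assay and not a number. Compound 2 `CNC(=O)c1cc(Oc2ccc3nc(Nc4cccc(Br)c4)ncc3c2)ccn1` likewise returns only the limit < 1 10^-6 cm/s. Compound 3 `CNC(=O)c1cc(Oc2ccc3nc(Nc4cccc(C(C)C)c4)ncc3c2)ccn1` also returns only the limit < 1 10^-6 cm/s. Because the limit of < 1 10^-6 cm/s in this assay, at which 3 of the 3 values shown sit, holds for every value in the set, none of the steps among these three can be read: a step that the two limits leave unreadable from compound 1 to compound 2, a step that the two limits leave unreadable from compound 1 to compound 3 and a step that the two limits leave unreadable from compound 2 to compound 3 all remain of unknown size. Compound 3 therefore stands only as a limit, with the two further values in the same position, and no numbered permeability exists anywhere in the series.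

Compound 4 `CNC(=O)c1cc(Oc2ccc3nc(Nc4ccc(C(C)C)cc4)ncc3c2)ccn1` differs from compound 3 by 4-isopropylphenyl in place of 3-isopropylphenyl on a nitrogen on an aromatic ring. Going by the values given here, none of the measured steps speaks to moving the isopropyl group to another position on the phenyl ring; the three measured steps change the substituent itself, and each is unreadable. The set gives neither a direction nor a size for the change. The expectation for compound 4 is that it again sits at the limit, with the estimated step being a step that the limit leaves unreadable from compound 3 to compound 4. The estimated permeability of compound 4 is 0.5 10^-6 cm/s, with a range from 0.1 10^-6 cm/s to 2 10^-6 cm/s.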

Compound 4, apparent permeability: < 1 10^-6 cm/s
Compound 4 ended at the assay's limit (the forecaster's own chance of this, stated with the estimate: 80%); the middle value does not contradict the limit.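

No step from compound 1, compound 2 or compound 3 to compound 4 can be read in this assay, because all four compounds sit at the same assay limit: the limit of < 1 10^-6 cm/s in this assay, at which 4 of the 4 values shown sit.

The compounds shown leave open what numerical permeability any of them has, and whether 4-isopropylphenyl and 3-isopropylphenyl differ on this read-out at all.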